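Trading an amino group for a methyl on the pyridyl arm

This account rests on a few compounds, and the source may have more. Where it says the series, first, only, none or still open, it means among the compounds named here.

Compounds measured so far:
compound 1, `O=c1ncn(Cc2c(F)cc(F)cc2F)c2ccc(Oc3cccc(-c4ccc5[nH]ccc5c4)c3C(F)(F)F)cc12`, giving 5.1 in a physicochemical assay for lipophilicity, at pH 7.4; on this read-out lower numbers stand for lower lipophilicity and higher numbers for higher lipophilicity;
compound 2, `Nc1ccc(-c2cccc(Oc3ccc4c(c3)c(=O)ncn4Cc3c(F)cc(F)cc3F)c2C(F)(F)F)cn1`, giving 3.9 in this assay.

Among the measured compounds shown here, compound 2 holds the lower of the two numbers; the one step measured, a number 1.20 log units lower from compound 1 to compound 2 (beyond the scatter), went with the swap of 1H-indol-5-yl for 6-aminopyridin-3-yl. Compound 3, `Cc1ccc(-c2cccc(Oc3ccc4c(c3)c(=O)ncn4Cc3c(F)cc(F)cc3F)c2C(F)(F)F)cn1`, differs from compound 2 only by methyl in place of amino on an aromatic carbon. For the measured compounds named here, no measured step mirrors this change directly, and the one step on record concerns a different group, so it bears on it only as an indication of how much this read-out can move. Removing the donor-and-acceptor amino group and adding a methyl is expected to raise this assay; for compound 3 the estimate is 4.8, with a range of 4.3 to 5.3, an expected step of a number 0.90 log units higher from compound 2 to compound 3 (beyond the scatter).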

Compound 3, distribution coefficient: 4.2
Compound 3: the middle estimate sits 0.60 log units above what was measured, outside the stated range (below it).
By their numbers in this assay, from the lowest: compounds 2 and 3 (each within the scatter of the next); then compound 1.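

In this assay the exchange of 6-aminopyridin-3-yl for 6-methylpyridin-3-yl gave a number 0.30 log units higher from compound 2 to compound 3 (within the scatter), so this read-out does not separate amino from methyl at this place. The indolyl comparison holds without the amino group, with 6-methylpyridin-3-yl in place of 1H-indol-5-yl giving a number 0.90 log units lower from compound 1 to compound 3 (beyond the scatter). Nothing on record accounts for this result. Open, on these data alone, is whether a methoxy group, a dimethylamino group or a nitrile at this place would also stay within the scatter of compound 2.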